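This account rests on a few compounds, and the source may have more. Where it says the series, first, only, none or still open, it means among the compounds named here.

Measured compounds in a functional assay on NCI-H226 cells (Homo sapiens) for inhibition; a lower number here means a stronger inhibitor of growth, a higher number a weaker inhibitor of growth:

compound 1 `O=C(/C=C/c1cccc(O)c1)c1cccc(-n2cc(-c3ccccc3)[nH]c2=O)c1` gives 24800 nM
compound 2 `O=C(/C=C/c1cccc(O)c1)c1cccc(-n2cc(-c3ccc(Cl)cc3)[nH]c2=O)c1` gives 2310 nM
compound 3 `COc1cc(/C=C/C(=O)c2cccc(-n3cc(-c4cc(OC)c(OC)c(OC)c4)[nH]c3=O)c2)cc(OC)c1OC` gives 14400 nM

Compound 2 stands lowest of the three numbers in this assay. Its nearest neighbour is compound 3, a clear distance away, and compound 1 is further still. Going by the values given here, the one step that can be followed directly is an 11-fold lower number from compound 1 to compound 2 (1.03 log units; beyond the scatter), which changes the ring on the other side of the shared core and is large.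

Compound 4 `COc1cc(/C=C/C(=O)c2cccc(-n3cc(-c4ccc(Cl)cc4)[nH]c3=O)c2)ccc1O` is not yet measured. It differs from compound 2 in this way: 4-hydroxy-3-methoxyphenyl in place of 3-hydroxyphenyl on a double-bonded chain carbon bound to a double-bonded chain carbon. Among the compounds with values here, no measured step changes this ring alone: compound 1 and compound 3 differ at both rings at once, so their values show only that compound 3 sits lower than compound 1. A step in this assay of moderate size at most is therefore expected from a 1.3-fold higher number from compound 2 to compound 4 (0.11 log units; within the scatter), in no assured direction. Compound 4 is estimated at 3000 nM, with a range from 1000 nM to 9000 nM.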

Compound 4, concentration for 50% growth inhibition: 2770 nM
Estimate against measurement, compound 4: 1.1-fold (0.03 log units) above, within the range that was stated.
By their numbers in this assay, from the lowest: compounds 2 and 4 (each within the scatter of the next); then compounds 3 and 1 (each within the scatter of the next).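

Going by these compounds alone, changing this ring alone gives a 1.2-fold higher number from compound 2 to compound 4 (0.08 log units; within the scatter) in this assay, a first direct reading at this position, since no earlier step isolated it. With the chloro group on the other ring kept in place, 4-hydroxy-3-methoxyphenyl can stand in for 3-hydroxyphenyl, despite its extra heavy atoms and additional hydrogen-bond acceptor, without a change in the number that can be told from scatter. Nothing shown here explains why the number holds.

On these data alone, this is a single replacement on a single partner, so it remains open whether the same swap would also leave the number unchanged in a compound without the chloro group. As far as these compounds go, it also remains open how far this position stays undemanding, for instance with an amine or a carboxylic acid on the ring.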